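The compounds below may be only part of what the source reports. "The series", "measured", "known", "first", "only" and "open" are said of these compounds alone.

Going by the values given here, in a functional assay on A-375 cells (Homo sapiens) for inhibition, with a stated time of 72 h (a lower number here means a stronger inhibitor, a higher number a weaker inhibitor), compound 1 (`CC(C)[C@H]1CC[C@@]2(CO2)[C@H]2C(=O)OCC(C(=O)OCc3ccc(-c4ccccc4)o3)=C[C@H]12`) gives 1310 nM and holds the lower of the two numbers so far. Compound 2 (`CC(C)[C@H]1CC[C@@](O)(CCl)[C@H]2C(=O)OCC(C(=O)OCc3ccc(-c4ccccc4)o3)=C[C@H]12`) gives 4000 nM, a gap beyond the scatter. Compound 3 (`CC(C)[C@H]1CC[C@@]2(CO2)[C@H]2C(=O)OCC(C(=O)OCc3ccc(-c4ccc([N+](=O)[O-])cc4)o3)=C[C@H]12`) differs from compound 1 by nitro in place of hydrogen on an aromatic carbon with nitro in place of hydrogen on an aromatic carbon, para to a large group (phenyl to 4-nitrophenyl). Among the compounds with values here, no measured pair covers this change, so the expectation is weakly founded. No step beyond the scatter is expected in this assay, and the estimate is a 1.3-fold lower number from compound 1 to compound 3 (0.12 log units; within the scatter) as a slight move to a lower number. For compound 3 the expected value is 1000 nM (estimated range 300 nM to 3500 nM).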

Compound 3, half-maximal inhibitory concentration: 1640 nM
For compound 3 the middle estimate is 1.6-fold (0.21 log units) below the measured one, within the range that was stated.
By their numbers in this assay, from the lowest: compounds 1 and 3 (each within the scatter of the next); then compound 2.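

In this assay, nitro in place of hydrogen on an aromatic carbon, para to a large group, gives a 1.3-fold higher number from compound 1 to compound 3 (0.10 log units; within the scatter). This position of the six-membered aromatic ring therefore accepts phenyl to 4-nitrophenyl without a step beyond the scatter, a point compound 2, changed elsewhere, could not address. Nothing available explains this result.

This rests on a single substituent at a single position. From the compounds shown here alone, whether an amine or a carboxylic acid at this position would give a step beyond the scatter remains open.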